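The compounds below may be only part of what the source reports. "The series", "measured", "known", "first", "only" and "open" are said of these compounds alone.

Measured so far in an assay for inhibition of kynurenine 3-monooxygenase (Rattus norvegicus), tested at 10 uM; a higher number here means more inhibition at the concentration tested (going by the name of the read-out), a lower number less inhibition:
- compound 1, `N/C(=C\C(=O)c1ccccc1)C(=O)O`: 17%
- compound 2, `N/C(=C\C(=O)c1ccc(Cl)cc1)C(=O)O`: 33%

Compound 2 stands highest of the two numbers; its nearest neighbour is compound 1, which sits a number 16 percentage points higher from compound 1 to compound 2 (beyond the scatter) below it, a modest step beyond the scatter brought by chloro in place of hydrogen on an aromatic carbon.

Compound 3, `N/C(=C\C(=O)c1ccc(F)cc1)C(=O)O`, is not yet measured. It differs from compound 2 as follows: fluoro in place of chloro on an aromatic carbon.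

Going by the values given here, only one measured step exists, and it does not swap one halogen for another; it shows that going from no substituent to chloro on that aromatic carbon gave the modest rise a number 16 percentage points higher from compound 1 to compound 2 (beyond the scatter). Replacing chloro by fluoro keeps a single-atom substituent at the same place, so the expectation is a number between the two measured values, closer to compound 2 than to compound 1, and the step is expected to be small, a number 8 percentage points lower from compound 2 to compound 3 (within the scatter), possibly within the scatter.

For compound 3 in this assay the expected inhibition is 25%, with a range from 12% to 38%.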

Compound 3, a percentage reported as inhibition, at one concentration (the size of the read-out at that concentration, not a potency): 41%
The estimate for compound 3 lay 16 percentage points below the measured number; the measured number lies above the stated range.
By their numbers in this assay, from the lowest: compound 1; then compounds 2 and 3 (each within the scatter of the next).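

In this assay the exchange of one halogen for the other at this position, on an aromatic carbon para to a group of 8 heavy atoms, gives a number 8 percentage points higher from compound 2 to compound 3 (within the scatter) and so does not separate fluoro from chloro. Fluoro in place of hydrogen gives a number 24 percentage points higher from compound 1 to compound 3 (beyond the scatter) and, read with a number 16 percentage points higher from compound 1 to compound 2 (beyond the scatter) from the earlier pair, this shows that the rise over the unsubstituted compound is not confined to chloro, since both halogen compounds stand beyond the scatter from compound 1. No measurement here offers an explanation for these numbers.

Whether a halogen is needed at this position remains open, as the compounds shown do not say how a methyl, a methoxy, a trifluoromethyl or an amine at the same aromatic carbon would compare with fluoro and chloro. Also open, on these data alone, are the effect of a halogen on the other aromatic carbons of the ring and how these single-concentration readings would translate into potency.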